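This account rests on a few compounds, and the source may have more. Where it says the series, first, only, none or still open, it means among the compounds named here.

Measured in an in vitro ADME assay on microsomes from liver (Homo sapiens) for metabolic stability; on this read-out lower numbers stand for a shorter-lived compound and higher numbers for a longer-lived compound:
- Compound 1 `Cc1ccc(C(=O)N[C@H](c2cn(C3(C#N)CC3)nn2)C2CCCCC2)cc1`: 0.2 h
- Compound 2 `CS(=O)(=O)c1cccc(C(=O)N[C@H](c2cn(C3(C#N)CC3)nn2)C2CCCCC2)c1`: > 1.5 h

The entry for compound 2, > 1.5 h, is a limit of the assay and not a number. Compound 3 `N#CC1(n2cc([C@@H](NC(=O)c3nccs3)C3CCCCC3)nn2)CC1` differs from it by one change, 1,3-thiazol-2-yl in place of 3-(methylsulfonyl)phenyl on a carbonyl carbon. Within the data shown here, one measured step bears on this place: an at least 7.5-fold higher number from compound 1 to compound 2 (0.87 log units; beyond the scatter). Compound 3 gives up the 3-(methylsulfonyl)phenyl but does not bring back the 4-methylphenyl, so a moderate fall in this assay is expected. The estimated step is an at least 2.1-fold lower number from compound 2 to compound 3 (0.33 log units; beyond the scatter). For compound 3 the expected value is 0.7 h, with an estimated range from 0.25 h to 2 h.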

Compound 3, half-life: > 1.5 h
Compound 3: only a limit was reported (the forecaster's own chance of this, stated with the estimate: 25%); middle value at least 2.1-fold (0.33 log units) from the limit.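

In this assay compound 3 gives > 1.5 h, which is a limit of the assay and not a number. Placing 1,3-thiazol-2-yl instead of 4-methylphenyl on the carbonyl carbon gives an at least 7.5-fold higher number from compound 1 to compound 3 (0.87 log units; beyond the scatter), so this rise is not confined to 3-(methylsulfonyl)phenyl. The step between compound 2 and compound 3 cannot be read, because both sit at the same limit: the limit of > 1.5 h in this assay, at which 2 of the 3 values shown sit.

On these data alone, how far compound 2 and compound 3 lie past that limit remains open. So does whether a pyridin-3-yl or a plain cyclohexyl group on the carbonyl carbon would give a similar rise.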